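Chloro for Fluoro in a Series Stuck at the Assay Limit

A few compounds are considered here, and "the series" means these few. Any claim that something is new, unique, unknown or untested is made for them only; others in the source may bear on it.

Of the compounds shown here, three that share one core have been tested in a functional assay on HeLa cells (Homo sapiens) for antiproliferative activity, read by MTT assay, with a stated time of 72 h (a lower number here means a stronger inhibitor, a higher number a weaker inhibitor), and none gave a number. Compound 1 `COc1cc(-n2ncnc2-c2cccc([N+](=O)[O-])c2)cc(OC)c1OC` returned only the limit > 10000 nM. Compound 2 `COc1cc(-n2ncnc2-c2ccc(F)cc2)cc(OC)c1OC` likewise returned only the limit > 10000 nM. Compound 3 `COc1cc(-c2ncnn2-c2ccc([N+](=O)[O-])cc2)cc(OC)c1OC`, which carries its nitro-bearing ring on the other side of the core, again returned only the limit > 10000 nM. Compound 2 therefore stands where every value in this set stands, at the limit of > 10000 nM in this assay, at which 3 of the 3 values shown sit, and nothing separates it from compound 1 or compound 3 on the numbers shown.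

The next compound, compound 4 `COc1cc(-n2ncnc2-c2ccc(Cl)cc2)cc(OC)c1OC`, differs from compound 2 in one place: chloro in place of fluoro on an aromatic carbon. Going by the values given here, no step between two measured compounds in this set carries a number, so no measured step can guide the size of this one. With all three measured compounds sitting at the limit, no shift beyond the scatter in this assay is expected, and the most likely outcome is that compound 4 is also reported only as a limit. The estimated step from compound 2 to compound 4 is a step that the limit leaves unreadable from compound 2 to compound 4. Compound 4 is thus expected to give about 15000 nM, within a range from 5000 nM to 50000 nM.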

Compound 4, half-maximal inhibitory concentration: > 10000 nM
Compound 4 was reported as a limit (the forecaster's own chance of this, stated with the estimate: 75%); the middle value does not contradict the limit.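

Compound 2 and compound 4 are both reported only as limits in this assay, so no step can be read for chloro in place of fluoro between them. The compounds shown leave open whether that exchange changes activity at all, and whether any compound on the shared core gives a measurable value: the limit of > 10000 nM in this assay, at which 4 of the 4 values shown sit.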